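A Methyl Added to the Aryl Imine of Compound 2

This account rests on a few compounds, and the source may have more. Where it says the series, first, only, none or still open, it means among the compounds named here.

The series begins with compound 1 `C=C1CN/C(=N/c2ccccc2)S1` and compound 2 `COc1ccc(/C=C2\S/C(=N\c3ccccc3)N(C)C2=O)cc1`, both of which share an exocyclic imine to a phenyl ring. In a functional assay on HCT-116 cells (Homo sapiens) for antiproliferative activity, read by MTT assay, with a stated time of 72 h (on this read-out lower numbers stand for stronger inhibition and higher numbers for weaker inhibition), compound 1 gives only a limit of the assay, > 100000 nM, and not a number. Compound 2 likewise gives only a limit in this assay, > 100000 nM, again not a number. Compound 3 `COc1ccc(/C=C2/CN(C)/C(=N/c3ccc(Br)cc3)S2)cc1` differs from compound 2 in several places. In this assay compound 3 gives 8900 nM, a number rather than a limit. Two of the three values shown therefore sit at the same boundary, (the limit of > 100000 nM in this assay, at which 2 of the 3 values shown sit), and compound 2 stands at that boundary with nothing measurable beneath it.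

Compound 4 `COc1ccc(/C=C2\S/C(=N\c3ccc(C)cc3)N(C)C2=O)cc1` carries one change from compound 2: methyl in place of hydrogen on an aromatic carbon, phenyl to 4-methylphenyl. Going by the values given here, no step between measured compounds mirrors this change, so the expectation rests on compound 2 alone. A single methyl on the aryl imine is expected to move the number little, and the step from compound 2 to compound 4 is estimated to stay within the scatter, a number no higher from compound 2 to compound 4 (the limit leaves the size open). Compound 4 is therefore expected to give about 100000 nM in this assay, within a range of 25000 nM to 400000 nM, most likely reported once more as a limit.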

Compound 4, half-maximal inhibitory concentration: > 100000 nM
Compound 4 ended at the assay's limit (the forecaster's own chance of this, stated with the estimate: 65%); the middle value sits exactly at the limit.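

In this assay compound 4, like compound 2, gives only a limit and not a number, so the step between them cannot be read: the limit of > 100000 nM in this assay, at which 3 of the 4 values shown sit. The compounds shown leave open whether methyl in place of hydrogen on this aromatic carbon changes the result in this assay at all.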